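Swapping a Benzyl for an Ethyl on the Ring Amine

The source may report more compounds than this note shows. Statements on the series, on what has been measured and on what is new or still open speak of the compounds shown alone.

Compound 1 `COc1cc(N)c(Cl)cc1C(=O)NCC1CCCN1Cc1ccccc1` was tested in a functional assay on the whole organism with Rattus norvegicus as the target (on this read-out lower numbers stand for an effect already at smaller amounts and higher numbers for an effect only at larger amounts of compound), where compound 1 gives 1.1 mg/kg. Compound 2 `CCN1CCCC1CNC(=O)c1cc(Cl)c(N)cc1OC` differs from it by methyl in place of phenyl on a saturated chain carbon bound to an amine nitrogen in a ring. For compound 2 the result in this assay is only a limit of the measurement, > 30 mg/kg. The step of an at least 27-fold higher number from compound 1 to compound 2 (1.43 log units; beyond the scatter) therefore rests on the limit of > 30 mg/kg in this assay, at which 1 of the 3 values shown sits, and is known only as a floor.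

Compound 3 `CNc1cc(OC)c(C(=O)NC2CCN(Cc3ccccc3)C2)cc1Cl` is built from the same atoms as compound 1, joined differently; the difference between the two cores is not broken down here. In this assay compound 3 gives 0.016 mg/kg. Compound 4 `CCN1CCC(NC(=O)c2cc(Cl)c(NC)cc2OC)C1` differs from compound 3 by methyl in place of phenyl on a saturated chain carbon bound to an amine nitrogen in a ring, the same change as before. A step of a 63-fold higher number from compound 3 to compound 4 (1.80 log units; beyond the scatter) is expected, a size resting on an at least 27-fold higher number from compound 1 to compound 2 (1.43 log units; beyond the scatter). Compound 4 is thus estimated to give about 1 mg/kg, most likely between 0.2 mg/kg and 10 mg/kg.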

Compound 4, dose for half-maximal effect: 10 mg/kg
Compound 4: the middle estimate sits 10-fold (1.00 log units) below what was measured; the measured number falls inside the stated range.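

In this assay the swap of benzyl for ethyl on the core of compound 3 gives a 630-fold higher number from compound 3 to compound 4 (2.80 log units; beyond the scatter) and so runs the same way as on the core of compound 1. Compound 2 gives > 30 mg/kg as a limit of the measurement and not a number. The direction of the change thus holds on both cores shown, but two pairs make no rule, and whether its size carries over stays unsettled: the same change on two cores in this assay, an at least 27-fold higher number (1.43 log units; beyond the scatter) from compound 1 to compound 2 and a 630-fold higher number (2.80 log units; beyond the scatter) from compound 3 to compound 4; the limit leaves it open whether they differ.

On these data alone, whether the aromatic ring or the length of the group matters more stays open. A cyclohexylmethyl group or a longer chain such as butyl in place of the benzyl would help to tell these apart.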